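This account rests on a few compounds, and the source may have more. Where it says the series, first, only, none or still open, it means among the compounds named here.

Compound 1 `O=S(=O)(c1cccc(F)c1)c1cnc2c(F)cccc2c1-c1cccc(Cl)c1` gives the lowest number of the three in an ADME assay on microsomes from liver (Homo sapiens) for metabolic stability, tested at 2.5 uM; on this read-out lower numbers stand for slow clearance and higher numbers for fast clearance: compound 1 shows 0.56 mL/min, compound 2 `O=S(=O)(c1cccc(F)c1)c1cnc2c(F)cccc2c1-c1cccc(F)c1` shows 1.14 mL/min and compound 3 `COc1ccc(-c2c(S(=O)(=O)c3cccc(F)c3)cnc3c(F)cccc23)cc1` shows 2.48 mL/min, so the steps run a 2.0-fold higher number from compound 1 to compound 2 (0.31 log units; beyond the scatter) and a 4.4-fold higher number from compound 1 to compound 3 (0.65 log units; beyond the scatter), with a 2.2-fold higher number from compound 2 to compound 3 (0.34 log units; beyond the scatter) between the other two. Compound 4 `Cc1ccc(S(=O)(=O)c2cnc3c(F)cccc3c2-c2cccc(Cl)c2)cc1F` differs from compound 1 by methyl in place of hydrogen on an aromatic carbon. For the measured compounds named here, none of the measured steps bears directly on this change: each of them alters the other aromatic ring, and all of them are modest. The step is therefore expected to stay close to the scatter, a 1.4-fold higher number from compound 1 to compound 4 (0.15 log units; within the scatter), as an estimate. In this assay compound 4 is expected to give about 0.8 mL/min, estimated within 0.4 mL/min to 1.6 mL/min.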

Compound 4, intrinsic clearance in a liver preparation (reported as CLH), per the amount of preparation that the assay uses: 3.18 mL/min
Compound 4: middle estimate off by 4.0-fold (0.60 log units), on the low side; measured number outside the range, above it.
By their numbers in this assay, from the lowest: compound 1; then compound 2; then compounds 3 and 4 (each within the scatter of the next).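

In this assay, the change from 3-fluorophenyl to 3-fluoro-4-methylphenyl gives a 5.7-fold higher number from compound 1 to compound 4 (0.75 log units; beyond the scatter). The 3-fluorophenyl group, the same in compounds 1, 2 and 3, thus proves to be a place where a single added methyl moves the read-out beyond the scatter. No measurement at hand accounts for this step.

On these data alone, what a chloro, a methoxy or a hydroxymethyl group would give at this same position remains open. As far as these compounds go, it is also open whether methyl here would give a similar step on compound 2 or compound 3.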